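The source may hold more compounds than are shown below. What is called first, only, known or untested is meant among the compounds shown, and "the series" means these compounds.

Working notes on the series. In a functional assay on K562 cells (Homo sapiens) for antiproliferative activity, with a stated time of 72 h (a higher number here means a weaker inhibitor, a lower number a stronger inhibitor), compound 1 `OC[C@H]1O[C@@H](n2cnc3c(NCc4cccc(F)c4)ncnc32)[C@H](O)[C@@H]1O` gives 7600 nM, compound 2 `OC[C@H]1O[C@@H](n2cnc3c(NCc4ccc(F)cc4)ncnc32)[C@H](O)[C@@H]1O` gives 2700 nM and compound 3 `OC[C@H]1O[C@@H](n2cnc3c(NCc4ccccc4Cl)ncnc32)[C@H](O)[C@@H]1O` gives 64000 nM. Compound 3 has the highest number of the three and is therefore the weakest inhibitor so far.

The next analogue is compound 4 `OC[C@H]1O[C@@H](n2cnc3c(NCc4ccccc4Br)ncnc32)[C@H](O)[C@@H]1O`. The change is bromo in place of chloro on an aromatic carbon, ortho to a large group.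

Within the data shown here, no measured pair isolates this exchange. The closest evidence is an 8.4-fold higher number from compound 1 to compound 3 (0.93 log units; beyond the scatter) and a 24-fold higher number from compound 2 to compound 3 (1.37 log units; beyond the scatter), but each of these steps changes both the halogen and its place on the ring. A change of place alone, from 3-fluorophenyl to 4-fluorophenyl, gives a 2.8-fold lower number from compound 1 to compound 2 (0.45 log units; beyond the scatter). The effect of exchanging one halogen for another at a fixed place remains unmeasured. The large steps in the series all involve a change of place, whereas here the place stays the same, so no step beyond the scatter is expected in this assay, and no direction can be supported.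

The expected result is a 1.2-fold lower number from compound 3 to compound 4 (0.07 log units; within the scatter). For compound 4 the estimated value is 55000 nM, with an expected range of 20000 nM to 130000 nM.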

Compound 4, half-maximal inhibitory concentration: 10000 nM
Estimate against measurement, compound 4: 5.5-fold (0.74 log units) above; measured number outside the range, below it.
By their numbers in this assay, from the lowest: compound 2; then compounds 1 and 4 (each within the scatter of the next); then compound 3.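

Working notes on the result. In this assay, among these compounds, holding the place fixed on an aromatic carbon, ortho to a large group, the exchange of chloro for bromo gives a 6.4-fold lower number from compound 3 to compound 4 (0.81 log units; beyond the scatter) and is the first measured halogen exchange, so a step beyond the scatter here does not need a change of place. With bromo at this place the compound gives a 1.3-fold higher number from compound 1 to compound 4 (0.12 log units; within the scatter) and, against the 4-fluorophenyl compound, a 3.7-fold higher number from compound 2 to compound 4 (0.57 log units; beyond the scatter) in the same assay, so a halogen at this place does not by itself bring the very weak number of compound 3. No measurement shown bears on the reason for the gap between chloro and bromo at this place.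

The compounds shown leave open whether the exchange of chloro for bromo has a similar size at the other two ring places, as no pair of 3-chlorophenyl and 3-bromophenyl or of 4-chlorophenyl and 4-bromophenyl compounds is at hand. They also leave open how iodo, methyl, methoxy or an amine would read at this same place.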